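The source may report more compounds than this note shows. Statements on the series, on what has been measured and on what is new or still open speak of the compounds shown alone.

Compound 1 `COc1cc(-c2cc(/C=C/C(=O)c3ccc(N)cc3)[nH]n2)cc(OC)c1OC` was tested in a functional assay on UACC-62 cells (Homo sapiens) for inhibition, read by sulforhodamine B assay, with a stated time of 48 h (a lower number here means that less compound is tolerated, a higher number that more compound is tolerated), where compound 1 gives 7510 nM. Compound 2 `COc1ccc(-c2cc(/C=C/C(=O)c3ccc(OC)c(OC)c3)[nH]n2)cc1` is the nearest of the measured compounds: in this assay compound 2 gives 6790 nM, a number within the usual scatter of that of compound 1, so the two cannot be told apart. Compound 3 `COc1cc(-c2cc(/C=C/C(=O)c3ccc(Cl)c(Cl)c3)[nH]n2)cc(OC)c1OC` in this assay gives > 100000 nM, which is a limit of the assay rather than a number. For the measured compounds named here, the one measured step, an at least 13-fold higher number from compound 1 to compound 3 (1.12 log units; beyond the scatter), concerns the group on the carbonyl carbon and is large.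

Compound 4 `COc1ccc(-c2cc(/C=C/C(=O)c3ccc(N)cc3)[nH]n2)cc1OC` differs from compound 1 elsewhere: hydrogen in place of methoxy on an aromatic carbon. Going by the values given here, no measured step touches this position, so the step from compound 1 to compound 3 gives no guidance on size or direction here, and the change itself is small, removing a single methoxy group. Compound 4 is therefore expected to sit close to compound 1, with a step of a 1.1-fold higher number from compound 1 to compound 4 (0.03 log units; within the scatter) that is not expected to exceed the scatter. The estimate for compound 4 in this assay is 8000 nM, between 3000 nM and 25000 nM.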

Compound 4, concentration lethal to 50% of the cells: 39600 nM
Compound 4: the middle estimate sits 5.0-fold (0.69 log units) below what was measured; measured number above the stated range.
By their numbers in this assay, from the lowest: compounds 2 and 1 (each within the scatter of the next); then compound 4. At a limit, above all of these: compound 3.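

Removing this single methoxy group is not a silent change: in this assay, with the 4-aminophenyl group on the carbonyl carbon unchanged, there is a 5.3-fold higher number from compound 1 to compound 4 (0.72 log units; beyond the scatter) and the number moves beyond the scatter. For the compounds shown here, the earlier step concerned only the group on the carbonyl carbon, so this is the first sign that the methoxy-bearing ring also matters in this assay, and more compound is tolerated without this methoxy group. Nothing shown here gives a cause for this step.

From the compounds shown here alone, whether a hydroxyl group or a fluorine atom on this aromatic carbon would keep the number near that of compound 1 remains open. So does whether removing this methoxy group has a similar effect when another group, such as 3,4-dichlorophenyl, sits on the carbonyl carbon.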